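The compounds below may be only part of what the source reports. "The series", "measured", "known", "first", "only" and "open" are said of these compounds alone.

Measured so far:
compound 1 `COCC#Cc1cn([C@H]2C[C@H](O)[C@@H](CO)O2)c(=O)[nH]c1=O` — > 200000 nM
compound 2 `CCC#Cc1cn([C@H]2C[C@H](O)[C@@H](CO)O2)c(=O)[nH]c1=O` — > 200000 nM

In an ADME assay on L1210/0 cells (Mus musculus) for cytotoxicity, with a stated time of 48 h (on this read-out lower numbers stand for stronger inhibition and higher numbers for weaker inhibition), compound 1 returns only the limit > 200000 nM, not a number. Compound 2 likewise returns only the limit > 200000 nM. The step that the two limits leave unreadable from compound 1 to compound 2 is therefore unreadable, as both values sit at the limit of > 200000 nM in this assay, at which 2 of the 2 values shown sit. For the measured compounds named here, compound 2 thus stands on a limit alone, and the one other value shown is a limit as well; no number within the range of this assay has been reached by either compound.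

Compound 3 is `O=c1[nH]c(=O)n([C@H]2C[C@H](O)[C@@H](CO)O2)cc1O`. The change from compound 2 is hydroxy in place of but-1-yn-1-yl on an aromatic carbon. Going by the values given here, no measured step of readable size bears on this change; the only step available is the unreadable one from compound 1 to compound 2. With nothing pointing toward a readable value, compound 3 is expected to sit at the same limit, the step of a number no higher from compound 2 to compound 3 (the limit leaves the size open) being an estimate of no change beyond the scatter. Compound 3 is estimated at 200000 nM, with a range of 50000 nM to 800000 nM, most likely reported again as a limit.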

Compound 3, half-maximal inhibitory concentration: > 200000 nM
Compound 3: only a limit was reported (the forecaster's own chance of this, stated with the estimate: 70%); the middle value sits exactly at the limit.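

The steps from compound 1 and compound 2 to compound 3 cannot be read, as all three compounds rest on one limit: the limit of > 200000 nM in this assay, at which 3 of the 3 values shown sit.

Open remains how compound 1, compound 2 and compound 3 compare in this assay and whether any change on the shared core gives a readable value.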